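This account rests on a few compounds, and the source may have more. Where it says the series, first, only, none or still open, it means among the compounds named here.

In a functional assay on A549 cells (Homo sapiens) for inhibition (a higher number here means a weaker inhibitor, a lower number a stronger inhibitor), compound 1 `COc1c([N+](=O)[O-])cc(/C=C/c2ccc3ccccc3c2)cc1[N+](=O)[O-]` gives > 5000 nM, which is a limit and not a measured number. Compound 2 `COc1c([N+](=O)[O-])cc(/C=C\c2ccc3ccccc3c2)cc1[N+](=O)[O-]` gives > 5000 nM, also a limit. Compound 3 `CN(C)c1c([N+](=O)[O-])cc(/C=C/c2ccc3ccccc3c2)cc1[N+](=O)[O-]` gives > 5000 nM, again a limit. For the measured compounds named here, the series so far therefore rests on (the limit of > 5000 nM in this assay, at which 3 of the 3 values shown sit), and compound 3 has no exact value to start from.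

Compound 4 `CN(C)c1c([N+](=O)[O-])cc(/C=C\c2ccc3ccccc3c2)cc1[N+](=O)[O-]` keeps every atom and bond of compound 3: the two compounds have the same atoms and bonds and differ only in configuration as drawn: 1 of 1 stereo elements differ; a double bond is drawn E in compound 3 and Z in compound 4. Going by the values given here, the closest precedent is the same double-bond change in the methoxy pair, a step that the two limits leave unreadable from compound 1 to compound 2. The replacement of methoxy by dimethylamino, a step that the two limits leave unreadable from compound 1 to compound 3, bears on it less directly. Neither step has a readable size, so neither gives a direction, and no change beyond the usual scatter is expected in this assay. The expected size of the change is a step that the limit leaves unreadable from compound 3 to compound 4. Compound 4 is most likely to reach the same limit, and its estimated value is 8000 nM, with an expected range of 3000 nM to 30000 nM.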

Compound 4, half-maximal inhibitory concentration: > 5000 nM
Compound 4: no number, only a limit; the forecaster's own chance of this, stated with the estimate: 85%; the middle value is on the limit's open side.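

Compound 4 gives > 5000 nM in this assay, which is a limit and not a number, so neither its step from compound 3 nor its step from compound 2 can be read. The compounds shown leave open whether double-bond configuration, or dimethylamino in place of methoxy, changes inhibition at all.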